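The source may report more compounds than this note shows. Statements on the series, on what has been measured and on what is new or still open speak of the compounds shown alone.

In a functional assay on A-375 cells (Homo sapiens) for activation, with a stated time of 3 days (a higher number here means that more compound is needed for the effect, a lower number that less compound is needed), compound 1 `O=C(Nc1ccc(-c2cscn2)cc1)C1CCCN(Cc2cccc(F)c2)C1` gives 5000 nM and compound 2 `O=C(Nc1ccc(-c2ncc[nH]2)cc1)C1CCCN(Cc2ccc(F)c(F)c2)C1` gives 8000 nM, two values within the scatter of each other. Compound 3 `O=C(Nc1ccc(-c2ccc[nH]2)cc1)C1CCCN(Cc2ccc(F)c(F)c2)C1`, not yet measured, differs from compound 2 in one place: it has 1H-pyrrol-2-yl in place of 1H-imidazol-2-yl on an aromatic carbon. For the measured compounds named here, no measured pair differs in only one place, so no measured step guides the expectation. The expected change is small, a 1.6-fold lower number from compound 2 to compound 3 (0.20 log units; within the scatter), an estimated step toward a lower number that stays within the scatter. Compound 3 is estimated at 5000 nM, with an expected range of 1500 nM to 15000 nM.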

Compound 3, half-maximal effective concentration: 720 nM
For compound 3 the middle estimate is 6.9-fold (0.84 log units) above the measured one; measured number outside the range, below it.
By their numbers in this assay, from the lowest: compound 3; then compounds 1 and 2 (each within the scatter of the next).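

In this assay, 1H-pyrrol-2-yl in place of 1H-imidazol-2-yl on this aromatic carbon, para to a large group, brings an 11-fold lower number from compound 2 to compound 3 (1.05 log units; beyond the scatter) and shows that this position is sensitive to the choice of five-membered aromatic ring. Both groups carry a hydrogen-bond donor, and only the leaving one carries a hydrogen-bond acceptor. No measurement at hand explains the size of this step. This reading rests on a single pair of compounds. Going by these compounds, it remains open whether a furan-2-yl ring or an amine at this position would give a similarly low number.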